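Phenyl for ethyl on the hydantoin series: second instance

The compounds below may be only part of what the source reports. "The series", "measured", "known", "first", "only" and "open" are said of these compounds alone.

Measured compounds:
compound 1, `CCCC1(c2ccccc2)NC(=O)N(Cc2ccc(C(=O)NO)cc2)C1=O`, in an assay on isolated protein for inhibition of protein deacetylase HDAC6 (Homo sapiens), read by fluorescence, with stated times of 10 min and 2 h (on this read-out lower numbers stand for stronger inhibition and higher numbers for weaker inhibition), gives 50.9 nM
compound 2, `O=C(NO)c1ccc(CN2C(=O)NC(Cc3ccccc3)(c3ccccc3)C2=O)cc1`, in this assay gives 71.9 nM
compound 3, `CCCN1C(=O)N(Cc2ccc(C(=O)NO)cc2)C(=O)C1CC(C)C`, in this assay gives 174 nM

Within the data shown here, the one counted step among the measured compounds is a 1.4-fold higher number from compound 1 to compound 2 (0.15 log units; within the scatter), the change being (phenyl in place of ethyl on a saturated chain carbon bound to a saturated ring carbon). Compound 3 stands at the highest of the three numbers, and its separation from compound 2 and from compound 1 is beyond the scatter in both cases. The difference between the core of compound 1 and the core of compound 3 is not broken down here.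

Compound 4, `CC(C)CC1C(=O)N(Cc2ccc(C(=O)NO)cc2)C(=O)N1Cc1ccccc1`, is not yet measured in this assay. It differs from compound 3 by phenyl in place of ethyl on a saturated chain carbon bound to an amide-type nitrogen in a ring. This is the same kind of change as that from compound 1 to compound 2, but not the same: there the place is on a saturated chain carbon bound to a saturated ring carbon, here on a saturated chain carbon bound to an amide-type nitrogen in a ring.

Among the measured compounds shown here, the only precedent is the step from compound 1 to compound 2, which stayed within the scatter. On that basis compound 4 is expected to sit close to compound 3, with an estimated step of a 1.2-fold higher number from compound 3 to compound 4 (0.08 log units; within the scatter). The estimate for compound 4 in this assay is 210 nM, with a range from 90 nM to 480 nM, the range widened because the place of the change differs from the precedent.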

Compound 4, half-maximal inhibitory concentration: 129 nM
Compound 4: middle estimate off by 1.6-fold (0.21 log units), on the high side, and the stated range covers the measured number.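

In this assay, phenyl in place of ethyl on a saturated chain carbon bound to an amide-type nitrogen in a ring gives a 1.3-fold lower number from compound 3 to compound 4 (0.13 log units; within the scatter), so this second instance of the change also stays within the scatter. Set beside the first instance, the two steps cannot be told apart: the same change on two cores in this assay, a 1.4-fold higher number (0.15 log units; within the scatter) from compound 1 to compound 2 and a 1.3-fold lower number (0.13 log units; within the scatter) from compound 3 to compound 4, 1.9-fold (0.28 log units) apart, within the scatter of two such steps. This shows that, in these two matched pairs, the change carries from one core to the other without a step beyond the scatter, but it does not show that the change is without effect on other cores, and the opposite directions of the two small steps cannot be read as a real difference between the cores; since core and place differ together between the pairs, the two pairs also cannot separate one from the other.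

The compounds shown leave open whether an amine, a carboxylic acid or a longer chain such as butyl in place of ethyl at either place would also stay within the scatter of its parent compound. They also leave open whether phenyl in place of ethyl would behave in the same way on a third core.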